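Chloro in Place of Fluoro at Compound 4

The source may report more compounds than this note shows. Statements on the series, on what has been measured and on what is new or still open speak of the compounds shown alone.

In a functional assay on HCT-116 cells (Homo sapiens) (on this read-out higher numbers stand for weaker inhibition of growth and lower numbers for stronger inhibition of growth), compound 1 `Cc1cc(C)c2c(O)cc(-c3ccc(Cl)cc3)nc2n1` gives 14800 nM and compound 2 `Oc1cc(-c2ccc(Cl)cc2)nc2ncccc12` gives 32400 nM while compound 3 `Cc1ccnc2nc(-c3ccc(F)cc3)cc(O)c12` gives 16200 nM on the same read-out. Compound 3 therefore stands within the usual scatter of compound 1 and also within that of compound 2. Compound 4 `Cc1ccnc2nc(-c3ccc(Cl)cc3)cc(O)c12` has not yet been measured. It differs from compound 3 in one place only chloro in place of fluoro on an aromatic carbon with chloro in place of fluoro on an aromatic carbon, para to a large group. Among the compounds with values here, compound 1 and compound 2 also carry chloro, but each differs from compound 3 in more than this one place, so no measured step shows this exchange alone. For that reason, no shift beyond the scatter is expected in either direction in this assay and the estimated 1.0-fold lower number from compound 3 to compound 4 (0.01 log units; within the scatter) stays within it. Compound 4 is expected at an estimated 16000 nM with a likely range from 8000 nM to 32000 nM in this measurement.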

Compound 4, concentration for 50% growth inhibition: 3720 nM
Compound 4: middle estimate off by 4.3-fold (0.63 log units), on the high side; the whole stated range lies above it.
By their numbers in this assay, from the lowest: compound 4; then compounds 1, 3 and 2 (each within the scatter of the next, the first and the last beyond it).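

In this assay, chloro in place of fluoro on an aromatic carbon, para to a large group, does not leave the number unchanged: the step gives a 4.4-fold lower number from compound 3 to compound 4 (0.64 log units; beyond the scatter). With chloro held in this place, methyl in place of hydrogen on an aromatic carbon also counts, giving an 8.7-fold lower number from compound 2 to compound 4 (0.94 log units; beyond the scatter). Hydrogen in place of methyl gives a 4.0-fold lower number from compound 1 to compound 4 (0.60 log units; beyond the scatter), so among these three chloro compounds, the number is lowest for compound 4, which has one methyl group, and the step is not a simple gain with each added methyl.

Nothing measured here explains why either exchange moves the number. The compounds shown leave open how bromo or methoxy would read at the halogen place, and how ethyl would read in place of the methyl group of compound 4.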